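Reintroducing a phenyl on the chain of a diaziridinyl quinone

A few compounds are considered here, and "the series" means these few. Any claim that something is new, unique, unknown or untested is made for them only; others in the source may bear on it.

Among the two measured compounds, compound 2 `COCCC1=C(N2CC2)C(=O)C(C)=C(N2CC2)C1=O` stands highest in a functional assay on L1210 cells (Mus musculus), with a stated time of 1 days (a lower number here means a less potent compound, a higher number a more potent compound, by a factor of ten per unit of this negative logarithm), where compound 2 gives 5.12. Its nearest neighbour is compound 1 `CC1=C(N2CC2)C(=O)C(Cc2ccccc2)=C(N2CC2)C1=O`, which in this assay gives 4.26; the step between them, a number 0.86 log units higher from compound 1 to compound 2 (beyond the scatter), amounts to methoxymethyl in place of phenyl on a saturated chain carbon bound to a double-bonded ring carbon. Compound 3 `CC1=C(N2CC2)C(=O)C(CCCc2ccccc2)=C(N2CC2)C1=O` has not yet been measured. Its difference from compound 2 is benzyl in place of methoxy on a saturated chain carbon, two bonds along the chain from a double-bonded ring carbon; the same difference, cut one bond further out, reads methoxymethyl to phenethyl. Going by the values given here, only the step from compound 1 to compound 2 bears on this change, and it runs partly in the opposite sense: there a phenyl left the chain and a methoxymethyl entered, raising the number; here the methoxy leaves and a benzyl enters, so a phenyl returns to the chain. A modest decrease in this assay is therefore expected, of a number 0.42 log units lower from compound 2 to compound 3 (beyond the scatter), though the phenyl now sits further out and the exact size is uncertain. Compound 3 is estimated at 4.7, within a range of 4.1 to 5.3.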

Compound 3, logarithm of the reciprocal of the active concentration, log(1/C): 3.6
The estimate for compound 3 lay 1.10 log units above the measured number; the whole stated range lies above it.
By their numbers in this assay, from the lowest: compound 3; then compound 1; then compound 2.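

Read against compound 2, the result shows that this position does not merely tolerate a phenyl further out on the chain: in this assay benzyl in place of methoxy on a saturated chain carbon, two bonds along the chain from a double-bonded ring carbon, gives a number 1.52 log units lower from compound 2 to compound 3 (beyond the scatter) and leaves the methoxy-bearing compound well ahead. Moving the phenyl outward also brought no recovery, since phenethyl in place of phenyl on a saturated chain carbon bound to a double-bonded ring carbon gives a number 0.66 log units lower from compound 1 to compound 3 (beyond the scatter) and so the longer phenyl-bearing chain stands lowest of the three, with neither phenyl compound reaching compound 2 and no compound shown going against that order. Nothing at hand accounts for either step.

As far as these compounds go, what the fall follows remains open, the aromatic ring or the length of the chain, as the three compounds do not separate the two. A plain butyl chain, or a chain of similar reach ending in a hydroxyl or an amine, would bear on that question, as would a longer ether chain on the side of compound 2.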